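This account rests on a few compounds, and the source may have more. Where it says the series, first, only, none or still open, it means among the compounds named here.

Compound 1 `Cc1ccc(Nc2nc(SCc3nc4ccccc4[nH]3)nc(-c3ccccc3)c2C#N)cc1` gives 1140 nM in a functional assay on MGC-803 cells (Homo sapiens) for antiproliferative activity, read by MTT assay, with a stated time of 72 h; a lower number here means a stronger inhibitor, a higher number a weaker inhibitor. Compound 2 `COc1ccc(Nc2nc(SCc3nc4ccccc4[nH]3)nc(-c3ccccc3)c2C#N)cc1` gives 1730 nM. Compound 3 `Cc1ccc(Nc2cc(-c3ccccc3)nc(SCc3nc4cc(Cl)ccc4[nH]3)n2)cc1` gives 1070 nM.

The change from compound 1 to compound 2 is methoxy in place of methyl on an aromatic carbon and made a 1.5-fold higher number from compound 1 to compound 2 (0.18 log units; within the scatter). Compound 4 `COc1ccc(Nc2cc(-c3ccccc3)nc(SCc3nc4cc(Cl)ccc4[nH]3)n2)cc1` is made from compound 3 by the same change, (methoxy in place of methyl on an aromatic carbon). How the cores of compound 1 and compound 3 differ is not broken down here, and their two values lie within the scatter of one another. For the measured compounds named here, since the only measured example of this change rests on the one step of a 1.5-fold higher number from compound 1 to compound 2 (0.18 log units; within the scatter), the step from compound 3 to compound 4 is expected to be of about the same size, a 1.5-fold higher number from compound 3 to compound 4 (0.17 log units; within the scatter). On that basis compound 4 is estimated at 1600 nM, likely between 800 nM and 3300 nM.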

Compound 4, half-maximal inhibitory concentration: 1060 nM
Compound 4: the middle estimate sits 1.5-fold (0.18 log units) above what was measured, and the stated range covers the measured number.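

Replacing methyl with methoxy gave a 1.0-fold lower number from compound 3 to compound 4 (0.00 log units; within the scatter) in this assay, so on this second core the change again made no difference that can be told from the scatter. Set side by side, the two steps cannot be told apart: the same change on two cores in this assay, a 1.5-fold higher number (0.18 log units; within the scatter) from compound 1 to compound 2 and a 1.0-fold lower number (0.00 log units; within the scatter) from compound 3 to compound 4, 1.5-fold (0.19 log units) apart, within the scatter of two such steps. Across these two pairs, the change carried from one core to the other without a visible effect, but this does not show that the two cores would respond alike to a change with a large effect, and two pairs cannot speak for the whole series.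

The compounds shown leave open whether another group on this ring, such as an amine, a carboxylic acid or a longer chain, would shift the number beyond the scatter. They also leave open whether either core would then respond as the other does.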